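Aryl swap on the fused core: from compound 2 to compound 3

The compounds below may be only part of what the source reports. "The series", "measured", "known", "first", "only" and "open" are said of these compounds alone.

Among the compounds with values here, the two measured members share one core and differ only in the aryl group attached to it. Compound 1 `COc1ccc(CN2C(=O)C(=O)c3cc(-c4cccc(OC)c4)ccc32)cc1` gives 100 nM in a functional assay on K562 cells (Homo sapiens) for antiproliferative activity, read by MTT assay, with a stated time of 48 h (a higher number here means a weaker inhibitor, a lower number a stronger inhibitor), and compound 2 `COc1ccc(CN2C(=O)C(=O)c3cc(-c4ccc(F)c(Cl)c4)ccc32)cc1` gives 380 nM. On these two numbers compound 2 stands highest, with compound 1 the nearest neighbour, and the step of a 3.8-fold higher number from compound 1 to compound 2 (0.58 log units; beyond the scatter) is the only one recorded so far.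

Compound 3 `COc1ccc(CN2C(=O)C(=O)c3cc(-c4ccc(C#N)cc4)ccc32)cc1` is not yet measured. Relative to compound 2 the change is 4-cyanophenyl in place of 3-chloro-4-fluorophenyl on an aromatic carbon. Within the data shown here, the one measured step touches the same position of the same core, so it is the only guide, and it was of modest size when a 3-chloro-4-fluorophenyl replaced a 3-methoxyphenyl. A 4-cyanophenyl is a third, distinct group, so the direction of the coming step is open; a step of comparable size in either direction, or none beyond the scatter, is plausible.

For compound 3 in this assay the expected value is 250 nM, within 80 nM to 800 nM, which corresponds to an expected step of a 1.5-fold lower number from compound 2 to compound 3 (0.18 log units; within the scatter).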

Compound 3, half-maximal inhibitory concentration: 260 nM
The estimate for compound 3 lay 1.0-fold (0.02 log units) below the measured number; measured number inside the range.
By their numbers in this assay, from the lowest: compound 1; then compounds 3 and 2 (each within the scatter of the next).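

In this assay the position now carries a third aryl group, and a 1.5-fold lower number from compound 2 to compound 3 (0.16 log units; within the scatter) leaves 4-cyanophenyl and 3-chloro-4-fluorophenyl indistinguishable, although the two have no substituent in common and only the entering group holds a nitrile with a hydrogen-bond acceptor. With a 2.6-fold higher number from compound 1 to compound 3 (0.41 log units; beyond the scatter) as well, 3-methoxyphenyl is set apart from both other aryl groups by steps beyond the scatter, which makes compound 1 the strongest inhibitor of the three and shows that a change at this position can matter without every change doing so. Nothing on hand gives a reason for this ordering.

Each pair shown changes the substituents and their places on the phenyl ring together, so the contribution of the methoxy group cannot be separated from that of its place on the ring. As far as these compounds go, how the bare phenyl, or a phenyl carrying an amine or a carboxylic acid, would compare at this position remains open, as does whether the aryl ranking holds when the other substituent on the shared core changes.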